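Adding methylsulfonyl to a compound at the assay limit

A few compounds are considered here, and "the series" means these few. Any claim that something is new, unique, unknown or untested is made for them only; others in the source may bear on it.

Compound 1 `C[C@H]1[C@H](NC(=O)OCCCCC2CCCCC2)C(=O)N1OCCCS(C)(=O)=O` and compound 2 `C[C@H]1[C@H](NC(=O)OCCCCC2CCCCC2)C(=O)N1Oc1ccccc1` share one core and differ only in the group on an oxygen. In an ADME assay on a cell-free system (plasma, Rattus norvegicus) for metabolic stability, read by LC-MS, with a stated time of 2 h, tested at 2 uM (on this read-out higher numbers stand for a longer-lived compound and lower numbers for a shorter-lived compound), compound 1 gives < 0.0834 h, which is a limit and not a number. In this assay compound 2 gives < 0.0834 h, again a limit. Compound 2 therefore has no exact value and stands with compound 1 at the limit of < 0.0834 h in this assay, at which 2 of the 2 values shown sit.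

Compound 3 `C[C@H]1[C@H](NC(=O)OCCCCC2CCCCC2)C(=O)N1Oc1ccc(S(C)(=O)=O)cc1` keeps everything in compound 2 except one place: methylsulfonyl in place of hydrogen on an aromatic carbon. Methylsulfonyl takes the place of hydrogen on an aromatic carbon, para to a large group. Among the compounds with values here, the only measured step bearing on this is a step that the two limits leave unreadable from compound 1 to compound 2, so it offers no size to carry over. Compound 1 has its methylsulfonyl in a 3-(methylsulfonyl)propyl group and still gives < 0.0834 h, which is a limit. No change beyond the usual scatter is therefore expected, and another limit is the likeliest report. The expected step is a step that the limit leaves unreadable from compound 2 to compound 3. For compound 3 the estimated half-life is 0.06 h, with an expected range from 0.02 h to 0.15 h.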

Compound 3, half-life in the plasma assay: < 0.0834 h
Compound 3 was reported as a limit; the forecaster's own chance of this, stated with the estimate: 85%; the middle value does not contradict the limit.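

Within the data shown here, compound 1, compound 2 and compound 3 all give a limit and not a number in the plasma assay, so no step between them can be read: the limit of < 0.0834 h in the plasma assay, at which 3 of the 3 values shown sit. In the plasma assay compound 3 gives < 0.0834 h, which is a limit and not a number.

The compounds shown leave open what exact half-life each has in the plasma assay, and so whether methylsulfonyl in place of hydrogen on an aromatic carbon changes it at all.

In a physicochemical assay for metabolic stability, read by HPLC, in phosphate buffer, with a stated time of 24 h, at 37 degrees C, at pH 7.4, tested at 1 uM, in the presence of a further agent that is not named here (on this read-out higher numbers stand for a longer-lived compound and lower numbers for a shorter-lived compound), compound 2 gives > 24 h, which is a limit and not a number. In the physicochemical assay compound 3 gives 12.1 h. In the physicochemical assay the data show an at least 1.9-fold lower number from compound 2 to compound 3 (0.29 log units; that floor lies within the scatter).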